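Ester in place of the amide side chain

The source may hold more compounds than are shown below. What is called first, only, known or untested is meant among the compounds shown, and "the series" means these compounds.

Of the compounds shown here, two have numbers so far. Compound 1 `CCn1c(C(=O)NCCCN(C)C)ccc1C(CC)(CC)c1ccc(OCC(=O)C(C)(C)C)c(C)c1` is the ethyl-substituted core carrying a (3-(dimethylamino)propyl)carbamoyl group and a ketone-bearing side chain on the phenol oxygen; in a functional assay on MCF7 cells (Homo sapiens), read by MTT assay, with a stated time of 48 h (on this read-out lower numbers stand for stronger inhibition and higher numbers for weaker inhibition), compound 1 gives 340 nM. Compound 2 `CCN(CC)CCCNC(=O)c1ccc(C(CC)(CC)c2ccc(OCC(O)C(C)(C)C)c(C)c2)n1CC` carries the (3-(diethylamino)propyl)carbamoyl group and the alcohol-bearing side chain; in this assay compound 2 gives 190 nM. Compound 2 has the lowest of the two numbers, but its gap to compound 1 lies within the scatter, so no order between the two can be read from this pair.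

Compound 3 `CCn1c(C(=O)OCc2ccc(F)cc2)ccc1C(CC)(CC)c1ccc(OCC(O)C(C)(C)C)c(C)c1` is the next compound to be measured. It differs from compound 2 at the carbonyl carbon whose other neighbour is an aromatic carbon: (4-fluorobenzyl)oxy in place of (3-(diethylamino)propyl)amino on a carbonyl carbon

For the measured compounds named here, no step between measured compounds is on hand for this kind of change, and both measured compounds share an amine-bearing carbamoyl group, so nothing shows how the ((4-fluorobenzyl)oxy)carbonyl group behaves. The expectation for compound 3 is a step of a 3.2-fold higher number from compound 2 to compound 3 (0.50 log units; beyond the scatter) toward weaker inhibition, with wide uncertainty. Compound 3 is estimated at 600 nM, within a range from 150 nM to 2500 nM.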

Compound 3, half-maximal inhibitory concentration: > 50000 nM
Compound 3: only a limit was reported; the forecaster's own chance of this, stated with the estimate: 10%; middle value at least 83-fold (1.92 log units) away from the limit.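

Placing (4-fluorobenzyl)oxy in place of (3-(diethylamino)propyl)amino on a carbonyl carbon gives an at least 260-fold higher number from compound 2 to compound 3 (2.42 log units; beyond the scatter) in this assay, so this position is sensitive to the group it carries, and this is the first step in the series beyond the scatter. Of the compounds shown, only compound 1 and compound 2 have numbers, and both carry an amine-bearing carbamoyl group, whereas compound 3, with the ((4-fluorobenzyl)oxy)carbonyl group, has neither the amide nitrogen nor the tertiary amine. Compound 3 has only a limit and not a number, so the step gives a minimum size rather than a full size: the limit of > 50000 nM in this assay, at which 1 of the 3 values shown sits.

The change replaces the amide link and the diethylamino-bearing chain in a single step, so the compounds shown cannot separate the contribution of either part. On these data alone, a 4-fluorobenzyl amide, an ester carrying the 3-(diethylamino)propyl chain, or a free carboxylic acid on the same carbonyl carbon would each bear on that question, and it remains open which part of the (3-(diethylamino)propyl)amino group matters.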